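Compound 3 and the cytotoxicity of a changed end group

A few compounds are considered here, and "the series" means these few. Any claim that something is new, unique, unknown or untested is made for them only; others in the source may bear on it.

Measured so far in an ADME assay on HepG2 2.2.15 cells (Homo sapiens) for cytotoxicity; on this read-out lower numbers stand for higher toxicity in this test and higher numbers for lower toxicity in this test
Compound 1 `O=C(OCCc1c(-c2ccccc2Cl)c2cc(Cl)ccc2[nH]c1=O)C1CCCCC1` gives 38000 nM
Compound 2 `O=C(CCC1CCCCC1)OCCc1c(-c2ccccc2Cl)c2cc(Cl)ccc2[nH]c1=O` gives 160000 nM

Compound 2 at 160000 nM holds the higher of the two numbers, which here means the lower toxicity. On a saturated chain carbon bound to a carbonyl carbon, compound 3 `O=C(CN1C(=O)c2ccccc2C1=O)OCCc1c(-c2ccccc2Cl)c2cc(Cl)ccc2[nH]c1=O` differs from compound 2 by a group of 11 heavy atoms (8 carbon, 1 nitrogen, 2 oxygen; one five-membered non-aromatic ring with 1 hetero atom, one six-membered aromatic ring of carbon only) in place of a group of 7 heavy atoms (7 carbon; one six-membered non-aromatic ring of carbon only), on a saturated chain carbon bound to a carbonyl carbon and nothing else. Going by the values given here, only one measured step bears on this end of the molecule. It is a 4.2-fold higher number from compound 1 to compound 2 (0.62 log units; beyond the scatter) and it counts as modest, with 2-cyclohexylethyl in place of cyclohexyl on a carbonyl carbon. Among the compounds with values here, both of those groups contain only carbon, and no measured compound carries the entering group, so the direction is uncertain. Within the data shown here, a modest step in this assay is expected, more likely downward, given that compound 2 holds the higher of only two numbers. The expected change is a 1.8-fold lower number from compound 2 to compound 3 (0.25 log units; within the scatter) by this estimate. For compound 3 the estimated value is 90000 nM (expected range 30000 nM to 250000 nM).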

Compound 3, half-maximal cytotoxic concentration: 960000 nM
Compound 3: middle estimate off by 11-fold (1.03 log units), on the low side; measured number outside the range, above it.
By their numbers in this assay, from the lowest: compound 1; then compound 2; then compound 3.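

In this assay, going by these compounds alone, the cyclohexylmethyl group gives way to a larger end group carrying nitrogen and oxygen as well as carbon, and the result is a 6.0-fold higher number from compound 2 to compound 3 (0.78 log units; beyond the scatter), so this position tolerates more than the all-carbon groups of the earlier compounds showed, with toxicity in this test falling further. Set against the cyclohexyl group on the carbonyl carbon, the change is a 25-fold higher number from compound 1 to compound 3 (1.40 log units; beyond the scatter), the only large step among these compounds. Nothing measured here explains this rise.

The entering group differs from the one it replaces in its rings and its atoms at once, so the compounds shown cannot say which of these matters. Going by these compounds, how a plain phenyl ring or a simple amine on that saturated chain carbon would behave remains open.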